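Thiocarbonyl-to-carbonyl swap on the sulfur of compound 1

The compounds below may be only part of what the source reports. "The series", "measured", "known", "first", "only" and "open" are said of these compounds alone.

Measured in an assay on HEK293 cells for inhibition of protein deacetylase HDAC6 (Homo sapiens); on this read-out higher numbers stand for weaker inhibition and lower numbers for stronger inhibition:
Compound 1 `CCOC(=S)SCC(=O)c1ccc(OC)cc1`: 448 nM
Compound 2 `CCSC(=S)SCC(=O)c1ccc(NS(C)(=O)=O)cc1`: 1090 nM
Compound 3 `CCOC(=S)SCC(=O)c1ccc(NC(C)=O)cc1`: 90 nM

Compound 1 gives the second highest number of the three; compound 2 sits a step higher and compound 3 a step lower, as a 5.0-fold lower number from compound 1 to compound 3 (0.70 log units; beyond the scatter) shows for an acetamido in place of methoxy on an aromatic carbon.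

Compound 4 `CCOC(=O)SCC(=O)c1ccc(OC)cc1` differs from compound 1 by a group of 5 heavy atoms (3 carbon, 2 oxygen; no ring) in place of a group of 5 heavy atoms (3 carbon, 1 oxygen, 1 sulfur; no ring), on a sulfur. Among the compounds with values here, none of the measured steps touches this part of the shared core; the only step known, from compound 1 to compound 3, concerns the aromatic substituent. There is thus no basis for a directed expectation, and the change is expected to leave the number near that of compound 1, with a wide range, as a 1.3-fold higher number from compound 1 to compound 4 (0.13 log units; within the scatter). Compound 4 is estimated at 600 nM, between 180 nM and 2500 nM.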

Compound 4, half-maximal inhibitory concentration: 5360 nM
Compound 4: middle estimate off by 8.9-fold (0.95 log units), on the low side, outside the stated range (above it).
By their numbers in this assay, from the lowest: compound 3; then compound 1; then compound 2; then compound 4.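

The sulfur position is not neutral. In this assay the ethoxycarbonyl group in place of the original sulfur-containing group gives a large change (a 12-fold higher number from compound 1 to compound 4 (1.08 log units; beyond the scatter)), although the counted heavy atoms, donors and acceptors stay the same. Nothing available accounts for this change.

From the compounds shown here alone, whether the same exchange has a similar effect with acetamido on the aromatic carbon, as in compound 3, stays open. So does the outcome with a longer chain or an amine in place of the ethoxy part of this group.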